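Replacing a fluoroethoxy carbamate arm with an isopropylsulfanyl thioester

A few compounds are considered here, and "the series" means these few. Any claim that something is new, unique, unknown or untested is made for them only; others in the source may bear on it.

Of the compounds shown here, two have been measured in a functional assay on CHO-K1 cells for agonist activity at Glucose-dependent insulinotropic receptor (Homo sapiens), read by a luciferase reporter, with a stated time of 5 h; on this read-out lower numbers stand for an effect already at smaller amounts and higher numbers for an effect only at larger amounts of compound. Compound 1 `CC(C)(C)OC(=O)N1CCC(Oc2ncnc3c2CCN3c2ccc(S(C)(=O)=O)cc2F)CC1` gives 20 nM and compound 2 `CS(=O)(=O)c1ccc(N2CCc3c(OC4CCN(C(=O)OCCF)CC4)ncnc32)c(F)c1` gives 501 nM, the higher of the two numbers, the step being a 25-fold higher number from compound 1 to compound 2 (1.40 log units; beyond the scatter). Compound 3 `CC(C)SC(=O)N1CCC(Oc2ncnc3c2CCN3c2ccc(S(C)(=O)=O)cc2F)CC1` differs from compound 2 by isopropylsulfanyl in place of 2-fluoroethoxy on a carbonyl carbon. Within the data shown here, only that one measured step bears on the same position, and it was large, so a change at this carbonyl can move the read-out well beyond the scatter. Compound 3 is therefore expected to come in at 80 nM, between 20 nM and 400 nM, a step of a 6.3-fold lower number from compound 2 to compound 3 (0.80 log units; beyond the scatter) in this assay.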

Compound 3, half-maximal effective concentration: 10 nM
Compound 3: the middle estimate sits 8.0-fold (0.90 log units) above what was measured; measured number below the stated range.
By their numbers in this assay, from the lowest: compounds 3 and 1 (each within the scatter of the next); then compound 2.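

In this assay, the carbonyl carbon accepts a sulfur-linked arm, with isopropylsulfanyl in place of 2-fluoroethoxy giving a 50-fold lower number from compound 2 to compound 3 (1.70 log units; beyond the scatter). Set against tert-butoxy, isopropylsulfanyl gives a 2.0-fold lower number from compound 1 to compound 3 (0.30 log units; within the scatter), so an oxygen at this link is not needed for a low number. Nothing measured here accounts for these steps.

The compounds shown do not separate the effect of the sulfur from that of the branched chain or the loss of fluorine. Isopropoxy or ethoxy on this carbonyl carbon would bear on that question.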